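The source may hold more compounds than are shown below. What is called first, only, known or untested is meant among the compounds shown, and "the series" means these compounds.

Compound 3 `Nc1nnc(SCc2coc3ccccc3c2=O)s1` gives 1500 nM in a functional assay on HEp-2 cells (Homo sapiens) for cytotoxicity, read by MTT assay, with a stated time of 72 h; on this read-out higher numbers stand for weaker inhibition and lower numbers for stronger inhibition. Compound 1 `Cc1nnc(SCc2coc3ccccc3c2=O)o1` differs from it by 5-methyl-1,3,4-oxadiazol-2-yl in place of 5-amino-1,3,4-thiadiazol-2-yl on a sulfur and gives 3800 nM, a step of a 2.5-fold higher number from compound 3 to compound 1 (0.40 log units; beyond the scatter). Compound 2 `Cc1ccc2oc(CSc3nnc(N)s3)cc(=O)c2c1` carries the 5-amino-1,3,4-thiadiazol-2-yl on another core; the difference between the two cores is not broken down here. In this assay compound 2 reaches only a limit, > 25000 nM, the line at which it sits being (the limit of > 25000 nM in this assay, at which 1 of the 3 values shown sits). Compound 4 `Cc1ccc2oc(CSc3nnc(C)o3)cc(=O)c2c1` is not yet measured; it differs from compound 2 by 5-methyl-1,3,4-oxadiazol-2-yl in place of 5-amino-1,3,4-thiadiazol-2-yl on a sulfur, the same kind of change at the same place as from compound 3 to compound 1. Since that change weakened inhibition, compound 4 is expected to start from a limit and to move further in the same direction, an estimated step that the limit leaves unreadable from compound 2 to compound 4. Compound 4 is therefore estimated at 60000 nM, between 20000 nM and 200000 nM, most likely reported again as a limit.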

Compound 4, half-maximal inhibitory concentration: > 25000 nM
Compound 4: no number, only a limit; the forecaster's own chance of this, stated with the estimate: 85%; the middle value does not contradict the limit.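

Compound 2 and compound 4 both stop at a limit in this assay, so no step between them can be read: the limit of > 25000 nM in this assay, at which 2 of the 4 values shown sit.

The compounds shown leave open how far 5-methyl-1,3,4-oxadiazol-2-yl in place of 5-amino-1,3,4-thiadiazol-2-yl shifts the number on the core of compound 2.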